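A Benzyl Group Carried Over to a Second Core

A few compounds are considered here, and "the series" means these few. Any claim that something is new, unique, unknown or untested is made for them only; others in the source may bear on it.

Compound 1 `NS(=O)(=O)Oc1ccc2c(c1)CN(C(=O)c1ccc(N3CCCCC3)cc1)CC2` and compound 2 `NS(=O)(=O)Oc1ccc2c(c1)CN(C(=O)c1cccc(N3CCCCC3)c1)CC2` are built from the same atoms joined differently; the difference between the two cores is not broken down here. In an assay on HEK293 cells for inhibition of Steryl-sulfatase (Homo sapiens), tested at 0.1 uM (a lower number here means a weaker effect, a higher number a stronger effect of the compound at the concentration tested), compound 1 gives 11.5%, and compound 2 gives 1%, the lowest of the three measured numbers. Compound 3 `NS(=O)(=O)Oc1ccc2c(c1)CN(C(=O)c1ccc(N3CCC(Cc4ccccc4)CC3)cc1)CC2` differs from compound 1 by benzyl in place of hydrogen on a saturated ring carbon, and that change gave a number 29.9 percentage points higher from compound 1 to compound 3 (beyond the scatter). In this assay compound 3 gives 41.4%. Compound 4 `NS(=O)(=O)Oc1ccc2c(c1)CN(C(=O)c1cccc(N3CCC(Cc4ccccc4)CC3)c1)CC2` differs from compound 2 by benzyl in place of hydrogen on a saturated ring carbon, the same change at the same place. In this assay, within the data shown here, the step from compound 2 to compound 4 is expected to be a number 21 percentage points higher from compound 2 to compound 4 (beyond the scatter), a rise of roughly the size seen once before, because a number 29.9 percentage points higher from compound 1 to compound 3 (beyond the scatter) is the only measured instance of this change. Compound 4 is thus estimated at 22%, likely between 5% and 42%.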

Compound 4, a percentage reported as inhibition, at one concentration (the size of the read-out at that concentration, not a potency): 1.4%
Beside the measured number, compound 4's estimate is 20.6 percentage points above it; the whole stated range lies above it.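

On the core of compound 2, the benzyl group gave a number 0.4 percentage points higher from compound 2 to compound 4 (within the scatter), so in this assay the rise seen on the core of compound 1 did not carry over. The two cores responded differently to the same change: the same change on two cores in this assay, a number 29.9 percentage points higher (beyond the scatter) from compound 1 to compound 3 and a number 0.4 percentage points higher (within the scatter) from compound 2 to compound 4, 29.5 percentage points apart, beyond the scatter of two such steps. A gain on one core therefore cannot be assumed on the other, but these two pairs do not show why the cores differ or how the change would behave on any further core.

The compounds shown leave open whether another group on the same saturated ring carbon, such as an amine, a carboxylic acid or a longer chain, would raise the number on the core of compound 2.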